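Sulfonylpiperazine variation on a xanthine A2b ligand

The source may hold more compounds than are shown below. What is called first, only, known or untested is meant among the compounds shown, and "the series" means these compounds.

Compound 2 `CCCn1c(=O)[nH]c2nc(-c3ccc(S(=O)(=O)N4CCN(c5ccc(C)cc5)CC4)cc3)[nH]c2c1=O` gives the lowest of the two numbers in an assay on CHO cells for displacement of a labelled ligand from adenosine receptor A2b (Homo sapiens), read by scintillation counting, with a stated time of 75 min, in the presence of a further agent that is not named here (on this read-out higher numbers stand for weaker inhibition and lower numbers for stronger inhibition), at 0.706 nM, while compound 1 `CCCn1c(=O)[nH]c2nc(-c3ccc(S(=O)(=O)N4CCN(c5ccc(Cl)cc5F)CC4)cc3)[nH]c2c1=O` gives 1.91 nM. Going by the values given here, the single measured step, a 2.7-fold lower number from compound 1 to compound 2 (0.43 log units; beyond the scatter), concerns only a change of one aryl group for another on that ring nitrogen. Among the compounds with values here, compound 3 `CCCn1c(=O)[nH]c2nc(-c3ccc(S(=O)(=O)N4CCN(C(C)c5ccccc5)CC4)cc3)[nH]c2c1=O` carries 1-phenylethyl in place of 4-methylphenyl on an amine nitrogen in a ring, a change no measured step covers directly. Compound 3 is therefore expected to lie near compound 2, with a step of a 2.1-fold higher number from compound 2 to compound 3 (0.33 log units; beyond the scatter) as the estimate. Compound 3 is estimated at 1.5 nM, within a range from 0.4 nM to 6 nM.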

Compound 3, inhibition constant: 8.34 nM
The estimate for compound 3 lay 5.6-fold (0.75 log units) below the measured number; measured number above the stated range.
By their numbers in this assay, from the lowest: compound 2; then compound 1; then compound 3.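

In this assay, this position on an amine nitrogen in a ring proved sensitive to more than the choice of aryl group: 1-phenylethyl carries a large penalty (a 12-fold higher number from compound 2 to compound 3 (1.07 log units; beyond the scatter)), greater than the modest difference seen between the two aryl groups. The penalty also holds against the other aryl group, though it is smaller (a 4.4-fold higher number from compound 1 to compound 3 (0.64 log units; beyond the scatter)). No measurement at hand accounts for this shift. As far as these compounds go, it remains open whether a benzyl group, lacking the methyl branch, would behave like 1-phenylethyl or like the aryl groups, and whether an amine on the phenyl ring would be accepted.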